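The source may hold more compounds than are shown below. What is called first, only, known or untested is meant among the compounds shown, and "the series" means these compounds.

Measured so far:
- compound 1 `Cn1cc(/C=C2/C(=O)Nc3ccccc32)c2cc(Nc3nccc(-c4ccc(O)cc4)n3)ccc21` in an ADME assay on RWPE-1 cells (Homo sapiens) for cytotoxicity, read by MTT assay, with a stated time of 48 h; a higher number here means a weaker inhibitor, a lower number a stronger inhibitor: 58400 nM
- compound 2 `Cn1cc(/C=C2/C(=O)Nc3ccccc32)c2cc(Nc3nccc(-c4ccc(Cl)cc4Cl)n3)ccc21` in this assay : "not determined" (no result reported)

Within the data shown here, compound 2 stands nowhere on the numbers: in this assay compound 2 has "not determined" (no result reported), so nothing can be said of how it compares with compound 1, and the only number is that of compound 1.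

Compound 3 `Cn1cc(/C=C2/C(=O)Nc3ccccc32)c2cc(Nc3nccc(-c4cccnc4)n3)ccc21` differs from compound 2 by pyridin-3-yl in place of 2,4-dichlorophenyl on an aromatic carbon. Among the measured compounds shown here, no step between measured compounds exists to size this change, and compound 2 itself carries no value, so any expectation rests on compound 1 alone. In this assay compound 1 gives 58400 nM, a weak effect, and the change from compound 2 to compound 3 is expected to leave the read-out in that same weak region, with any difference from compound 1 not beyond the usual scatter. Compound 3 is expected to give 55000 nM, within the range 18000 nM to 160000 nM.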

Compound 3, half-maximal inhibitory concentration: 69800 nM
The estimate for compound 3 lay 1.3-fold (0.10 log units) below the measured number; the range from low to high includes it.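

In this assay this aromatic carbon now has its first readable step, a 1.2-fold higher number from compound 1 to compound 3 (0.08 log units; within the scatter), with pyridin-3-yl in place of 4-hydroxyphenyl. The position thus takes a six-membered aromatic ring with one hetero atom or a carbon-only ring bearing a hydroxyl group with no change that can be separated from the scatter, and both compounds stay in the same weak region. No measurement in hand bears on why these two groups read alike.

Compound 2 has no number, so 2,4-dichlorophenyl cannot be placed against the other two groups. From the compounds shown here alone, whether a non-aromatic group on this carbon, such as morpholine or a simple amine, or a carboxylic acid on the phenyl ring, would move the read-out beyond the scatter stays open.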